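Carboxy to Methyl on a Shared Bicyclic Core

The source may hold more compounds than are shown below. What is called first, only, known or untested is meant among the compounds shown, and "the series" means these compounds.

Compound 3 `CCCc1nc(C)c2c(C)nn(CC(=O)O)c(=O)n12` is inhibited only to a limit of the assay in a functional assay for inhibition, with Homo sapiens as the target (a lower number here means a stronger inhibitor, a higher number a weaker inhibitor), recorded as > 48000 nM. Compound 2 `CCCc1nc(C)c2c(C)nn(CC(O)CO)c(=O)n12` likewise stops at the limit > 48000 nM. Compound 1 `Cc1nc(-c2ccccc2)n2c(S)nncc12`, which has a different core, also reaches only the limit > 48000 nM. For the measured compounds named here, the one measured step, a step that the two limits leave unreadable from compound 2 to compound 3, is therefore unreadable: both of its ends are limits and no size can be taken from it. Compound 3 thus stands nowhere that a number could fix; it shares the same limit with the other two measured compounds, as the limit of > 48000 nM in this assay, at which 3 of the 3 values shown sit, records.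

The change to compound 4 `CCCc1nc(C)c2c(C)nn(CC)c(=O)n12` is methyl in place of carboxy on a saturated chain carbon bound to an aromatic nitrogen. Going by the values given here, no measured step bears on this change, and the single step that was measured cannot be read, so there is no measured ground for expecting a shift of any size or direction in this assay. With every measured compound at the limit, compound 4 is expected to remain at or near that limit, and its estimated value is 48000 nM, within a range of 15000 nM to 150000 nM. The step this estimate implies, a number no higher from compound 3 to compound 4 (the limit leaves the size open), is expected to be none beyond the scatter.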

Compound 4, half-maximal inhibitory concentration: > 48000 nM
Compound 4 gave a limit, no number; the forecaster's own chance of this, stated with the estimate: 75%; the middle value lies on the limit itself.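

In this assay compound 4 gives > 48000 nM, which is a limit and not a number. The steps from compound 2 and from compound 3 to compound 4 cannot be read, as each has a limit at both ends. The compounds shown leave open how strongly any of them inhibits, and whether these chain changes alter inhibition at all: the limit of > 48000 nM in this assay, at which 4 of the 4 values shown sit.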